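The source may hold more compounds than are shown below. What is called first, only, known or untested is meant among the compounds shown, and "the series" means these compounds.

Compound 1, `CCN(CC)S(=O)(=O)c1ccc(S(=O)(=O)N2CCC[C@@H](C(=O)N3CCC(F)(F)CC3)C2)cc1`, was tested in a functional assay on MIA PaCa-2 cells (Homo sapiens) for inhibition, read by MTT assay, with a stated time of 3 days; a lower number here means a stronger inhibitor, a higher number a weaker inhibitor. There compound 1 reached only the limit of the assay, > 10000 nM, and no number. Compound 2, `CCN(CC)S(=O)(=O)c1ccc(S(=O)(=O)N2CCC[C@@H](C(=O)N3CCC(OC)CC3)C2)cc1`, stands at the same kind of limit: in this assay compound 2 gives > 10000 nM. Compound 3, `CCN(CC)S(=O)(=O)c1ccc(S(=O)(=O)N2CCC[C@@H](C(=O)N3CCC(COC)CC3)C2)cc1`, likewise gives > 10000 nM in this assay, a limit rather than a number. The steps among these three compounds are therefore unreadable: a step that the two limits leave unreadable from compound 1 to compound 2, a step that the two limits leave unreadable from compound 1 to compound 3 and a step that the two limits leave unreadable from compound 2 to compound 3. What the three share is the limit of > 10000 nM in this assay, at which 3 of the 3 values shown sit. Compound 4, `CCN(CC)S(=O)(=O)c1ccc(S(=O)(=O)N2CCC[C@@H](C(=O)N3CC[C@H](OC)C3)C2)cc1`, differs from compound 1 in one place: 3-methoxypyrrolidin-1-yl in place of 4,4-difluoropiperidin-1-yl on a carbonyl carbon. Among the measured compounds shown here, no measured step bears on this change in a readable way; every step among the measured compounds is hidden by the limit, and the three measured compounds show only that three different groups on a carbonyl carbon all leave the compound at the limit. Compound 4 is therefore expected to sit at the limit as well, with a step that the limit leaves unreadable from compound 1 to compound 4 as the step this expectation means. The estimate for compound 4 in this assay is 15000 nM, within 8000 nM to 40000 nM.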

Compound 4, half-maximal inhibitory concentration: > 10000 nM
Compound 4 ended at the assay's limit; the forecaster's own chance of this, stated with the estimate: 85%; the middle value is on the limit's open side.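

Compound 4 joins compound 1, compound 2 and compound 3 at a limit rather than a number, so no step from any of them to compound 4 can be read: the limit of > 10000 nM in this assay, at which 4 of the 4 values shown sit.

The compounds shown leave open what change to the shared core, if any, would give a measurable value in this assay.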